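The compounds below may be only part of what the source reports. "The series", "measured", "known", "first", "only" and "open" are said of these compounds alone.

Compound 1 `Cc1ccc(NC(=O)c2cccc(C(F)(F)F)c2)cc1OC1CCN(C(=O)c2cccnc2)CC1` gives in an ADME assay on BaF3 cells (Mus musculus) for antiproliferative activity (on this read-out higher numbers stand for weaker inhibition of growth and lower numbers for stronger inhibition of growth), the limit > 10000 nM.
Compound 2 `Cc1ccc(NC(=O)c2cc(Cl)cc(C(F)(F)F)c2)cc1OC1CCN(C(=O)c2cccnc2)CC1` gives in this assay the limit > 10000 nM.
Compound 3 `Cc1ccc(NC(=O)c2cc(Cl)cc(C(F)(F)F)c2)cc1OC1CCN(C(=O)c2ccno2)CC1` gives in this assay the limit > 10000 nM.

Compound 2 therefore stands only at a limit in this assay, with no number of its own, and the two other values shown share that situation (the limit of > 10000 nM in this assay, at which 3 of the 3 values shown sit). Two steps have been measured among these compounds. The step that the two limits leave unreadable from compound 1 to compound 2 adds a chlorine to an aromatic carbon, and the step that the two limits leave unreadable from compound 2 to compound 3 exchanges the group on the carbonyl carbon of the piperidine amide; neither can be read in size, since both ends sit at the limit.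

Compound 4 `Cc1ccc(NC(=O)c2cc(C(C)(C)C)on2)cc1OC1CCN(C(=O)c2cccnc2)CC1` differs from compound 2 by 5-(tert-butyl)-1,2-oxazol-3-yl in place of 3-chloro-5-(trifluoromethyl)phenyl on a carbonyl carbon. For the measured compounds named here, no measured step touches this part of the core, so nothing among the values shown points in either direction. With every value at the limit, compound 4 is expected to give about 15000 nM, within 3000 nM to 60000 nM, and the step from compound 2 is estimated as a step that the limit leaves unreadable from compound 2 to compound 4, most likely again only a limit.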

Compound 4, concentration for 50% growth inhibition: > 10000 nM
Compound 4 ended at the assay's limit; the forecaster's own chance of this, stated with the estimate: 70%; the middle value does not contradict the limit.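

Compound 4 also stands only at a limit, so its steps from compound 1 and from compound 2 cannot be read in size: the limit of > 10000 nM in this assay, at which 4 of the 4 values shown sit.

The compounds shown leave open whether any of these changes affects growth inhibition in this assay; none of them has a number of its own.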